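Fluoro to Methoxy on the Aryl Ring: Expected Permeability

This account rests on a few compounds, and the source may have more. Where it says the series, first, only, none or still open, it means among the compounds named here.

Measured compounds:
Compound 1 `COc1ccc(F)cc1CNCCCNc1ccnc2cc(C3CCCCC3)ccc12`: 23 10^-6 cm/s
Compound 2 `Fc1ccc(-c2ccc3c(NCCCNCc4ccco4)ccnc3c2)cc1`: 237 10^-6 cm/s
Compound 3 `COc1ccc(F)cc1CNCCCNc1ccnc2cc(Cc3ccc(F)cc3)ccc12`: 23 10^-6 cm/s

In an ADME assay for permeability, using PAMPA, with a stated time of 30 min, at pH 7.4 (a higher number here means that the compound crosses the layer faster, a lower number that the compound crosses the layer more slowly), compound 2 gives the highest of the three numbers, well beyond the scatter above compound 1 and compound 3. The new compound 4 `COc1ccc(-c2ccc3c(NCCCNCc4ccco4)ccnc3c2)cc1` differs from compound 2 by methoxy in place of fluoro on an aromatic carbon. Among the compounds with values here, no measured pair shows this exact change. Within the data shown here, the only measured step, no change at the digits printed from compound 1 to compound 3 (within the scatter), alters a different part of the shared core and had no effect, so it bears only loosely here. Compound 4 is therefore expected to stay near compound 2, with at most a modest fall, a 1.3-fold lower number from compound 2 to compound 4 (0.12 log units; within the scatter), within the usual scatter. The estimate for compound 4 is 180 10^-6 cm/s, ranging from 80 10^-6 cm/s to 350 10^-6 cm/s.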

Compound 4, apparent permeability: 237 10^-6 cm/s
Estimate against measurement, compound 4: 1.3-fold (0.12 log units) below, within the range that was stated.
By their numbers in this assay, from the lowest: compounds 1 and 3 (each within the scatter of the next); then compounds 2 and 4 (each within the scatter of the next).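

In this assay, the change from 4-fluorophenyl to 4-methoxyphenyl gives no change at the digits printed from compound 2 to compound 4 (within the scatter). The earlier compounds shown here held no pair that varied this position, and now one shows that, on an aromatic carbon para to a large group, methoxy can take the place of fluoro with no readable shift in this read-out. Nothing available explains this result.

From the compounds shown here alone, whether an amine or a carboxylic acid in the same place would also leave the number unchanged remains open. So does whether this change would behave alike in compounds with a different side chain.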